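Aryl amide variation on a shared core: compound 3 outlook

The source may report more compounds than this note shows. Statements on the series, on what has been measured and on what is new or still open speak of the compounds shown alone.

Measured so far:
compound 1 `COc1ccc2c(=O)c(/C=C/C(=O)NCc3ccccc3F)coc2c1` — > 200000 nM
compound 2 `COc1ccc2c(=O)c(/C=C/C(=O)Nc3ccccc3OC)coc2c1` — > 200000 nM

In a functional assay on L02 cells (Homo sapiens) for inhibition, read by MTT assay, with a stated time of 48 h (a lower number here means a stronger inhibitor, a higher number a weaker inhibitor), compound 1 reaches only the limit > 200000 nM, not a number. Compound 2 likewise stands at the limit > 200000 nM in this assay, so its position on the scale is known only as a bound. Both values sit at the limit of > 200000 nM in this assay, at which 2 of the 2 values shown sit, and the step that the two limits leave unreadable from compound 1 to compound 2 is therefore unreadable.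

Compound 3 `CCOc1ccc(NC(=O)/C=C/c2coc3cc(OC)ccc3c2=O)cc1` differs from compound 2 by 4-ethoxyphenyl in place of 2-methoxyphenyl on an amide-type nitrogen. Within the data shown here, no readable measured step bears on this change; the only step, a step that the two limits leave unreadable from compound 1 to compound 2, gives no size or direction. Compound 3 is expected to give 200000 nM (range 60000 nM to 600000 nM), most likely again a limit, implying an expected step of a number no higher from compound 2 to compound 3 (the limit leaves the size open) within the scatter.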

Compound 3, half-maximal inhibitory concentration: > 200000 nM
Compound 3: a limit, no number; the forecaster's own chance of this, stated with the estimate: 80%; the middle value lies on the limit itself.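

Compound 3 gives > 200000 nM, a limit and not a number, so the steps from compound 1 and from compound 2 to compound 3 cannot be read: the limit of > 200000 nM in this assay, at which 3 of the 3 values shown sit.

The compounds shown leave open whether these amide groups differ at all in this assay.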